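The source may report more compounds than this note shows. Statements on the series, on what has been measured and on what is new or still open speak of the compounds shown alone.

Compound 1 `COc1cc(C(=O)c2sc3ccccc3c2-c2ccc(F)cc2)cc(OC)c1OC`: 3200 nM
Compound 2 `COc1cc(C(=O)c2sc3ccccc3c2-c2ccc(C)cc2)cc(OC)c1OC`: 7800 nM

In a functional assay on A549 cells (Homo sapiens) for antiproliferative activity, read by MTT assay, with a stated time of 72 h (on this read-out higher numbers stand for weaker inhibition and lower numbers for stronger inhibition), compound 2 gives 7800 nM, the higher of the two numbers, so it is the weaker inhibitor of the pair. Compound 3 `COc1ccc(-c2c(C(=O)c3cc(OC)c(OC)c(OC)c3)sc3ccccc23)cc1` keeps the shared core and swaps one group of compound 2, with methoxy in place of methyl on an aromatic carbon. Among the compounds with values here, only one measured step bears on this, and it concerns the same aromatic carbon: a 2.4-fold higher number from compound 1 to compound 2 (0.39 log units; beyond the scatter). That step is modest, though beyond the scatter. Within the data shown here, no methoxy compound has been measured yet, so the direction stays open, and a similarly modest step at most is expected, leaning slightly towards a lower number. The expected step is a 1.3-fold lower number from compound 2 to compound 3 (0.11 log units; within the scatter). For compound 3 the estimated value is 6000 nM, with an expected range from 2000 nM to 16000 nM.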

Compound 3, half-maximal inhibitory concentration: 4400 nM
Compound 3: the middle estimate sits 1.4-fold (0.13 log units) above what was measured; low and high end bracket the measured number.
By their numbers in this assay, from the lowest: compounds 1, 3 and 2 (each within the scatter of the next, the first and the last beyond it).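

In this assay, methoxy in place of methyl gives a 1.8-fold lower number from compound 2 to compound 3 (0.25 log units; within the scatter), and methoxy in place of fluoro gives a 1.4-fold higher number from compound 1 to compound 3 (0.14 log units; within the scatter). Both steps lie within the scatter, so the methoxy compound cannot be told apart from either of the others, even though compound 1 and compound 2 differ from each other beyond the scatter; adding an oxygen and a hydrogen-bond acceptor at this position opens no new, readable difference. No measurement shown here offers an explanation for these numbers.

On these data alone, whether an amine, a carboxylic acid or a longer chain such as ethoxy on this aromatic carbon would move the number clearly beyond the scatter remains open. So does whether the group on this ring matters much at all beyond the difference between fluoro and methyl.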